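This account rests on a few compounds, and the source may have more. Where it says the series, first, only, none or still open, it means among the compounds named here.

Values in a functional assay on HepG2 cells (Homo sapiens) for inhibition, read by sulforhodamine B assay, with a stated time of 74 h; a lower number here means a stronger inhibitor, a higher number a weaker inhibitor:
Compound 1 `O=C1C=CC2(C=C1)OCC(=O)N2S(=O)(=O)c1ccccc1`: > 10000 nM, a limit
Compound 2 `N#Cc1cccc(S(=O)(=O)N2C(=O)COC23C=CC(=O)C=C3)c1`: > 10000 nM, a limit
Compound 3 `O=C1C=CC2(C=C1)OCC(=O)N2S(=O)(=O)c1ccc(C(F)(F)F)cc1`: 750 nM

Compound 2 stands only at a limit: the limit of > 10000 nM in this assay, at which 2 of the 3 values shown sit. Compound 4 `O=C1C=CC2(C=C1)OCC(=O)N2S(=O)(=O)c1cccc(C(F)(F)F)c1` has trifluoromethyl in place of cyano on an aromatic carbon, meta to a large group: trifluoromethyl in place of cyano on an aromatic carbon. The cyano step gives no size: a step that the two limits leave unreadable from compound 1 to compound 2. Trifluoromethyl gives the one readable step, an at least 13-fold lower number from compound 1 to compound 3 (1.12 log units; beyond the scatter); there it sits on another aromatic carbon than in compound 4. Compound 3 at 750 nM is the ground for expecting a large move to a lower number in this assay. The expected move is an at least 6.6-fold lower number from compound 2 to compound 4 (0.82 log units; beyond the scatter). The estimate for compound 4 is 1500 nM, with an expected range of 400 nM to 8000 nM.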

Compound 4, half-maximal inhibitory concentration: > 10000 nM
Compound 4 was reported as a limit; the forecaster's own chance of this, stated with the estimate: 20%; middle value at least 6.6-fold (0.82 log units) away from the limit.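

In this assay compound 4 gives > 10000 nM, a limit. Within the data shown here, no step from compound 1 or compound 2 to compound 4 can be read. How compound 1, compound 2 and compound 4 compare with one another stays open: the limit of > 10000 nM in this assay, at which 3 of the 4 values shown sit.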